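From trifluoromethyl to methyl on a shared core

This account rests on a few compounds, and the source may have more. Where it says the series, first, only, none or still open, it means among the compounds named here.

In a functional assay on HeLa cells (Homo sapiens) for antiproliferative activity, read by MTT assay, with a stated time of 48 h (on this read-out higher numbers stand for weaker inhibition and lower numbers for stronger inhibition), compound 1 `COc1ccc(-c2nn(-c3ccccc3)cc2-c2nc3cc(Br)ccc3[nH]2)cc1` gives 1060 nM and compound 2 `COc1ccc(-c2nn(-c3ccccc3)cc2-c2nc3cc(C(F)(F)F)ccc3[nH]2)cc1` gives 2760 nM as the higher of the two numbers. Compound 3 `COc1ccc(-c2nn(-c3ccccc3)cc2-c2nc3cc(C)ccc3[nH]2)cc1` differs from compound 2 in one place, with methyl in place of trifluoromethyl on an aromatic carbon and the rest of the core kept. Among the measured compounds shown here, the only measured step of a 2.6-fold higher number from compound 1 to compound 2 (0.42 log units; beyond the scatter) is modest and came with trifluoromethyl in place of bromo on an aromatic carbon. With that single guide, a modest step of a 1.8-fold lower number from compound 2 to compound 3 (0.26 log units; within the scatter) toward a lower number is expected. Compound 3 is estimated at 1500 nM in this assay with 700 nM to 3200 nM as its expected range.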

Compound 3, half-maximal inhibitory concentration: 3290 nM
Compound 3: middle estimate off by 2.2-fold (0.34 log units), on the low side; measured number outside the range, above it.
By their numbers in this assay, from the lowest: compound 1; then compounds 2 and 3 (each within the scatter of the next).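

In this assay, methyl in place of trifluoromethyl on this aromatic carbon gives a 1.2-fold higher number from compound 2 to compound 3 (0.08 log units; within the scatter), so the two groups cannot be told apart here, although one carries three fluorine atoms and the other none. Bromo alone stands apart, as methyl in its place gives a 3.1-fold higher number from compound 1 to compound 3 (0.49 log units; beyond the scatter), and compound 1 keeps the lowest number of the three. Nothing available explains why bromo differs. Going by these compounds, whether an amine or a carboxylic acid on this carbon would match bromo, match methyl or fall elsewhere stays open.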